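A few compounds are considered here, and "the series" means these few. Any claim that something is new, unique, unknown or untested is made for them only; others in the source may bear on it.

Measured compounds:
compound 1 `N#Cc1c(Nc2ccccc2F)nc(SCc2cn(Cc3ccccc3Cl)nn2)nc1-c1ccccc1` gives 23000 nM in a functional assay on ECa-109 cells (Homo sapiens) for inhibition, read by MTT assay, with a stated time of 72 h; a higher number here means a weaker inhibitor, a lower number a stronger inhibitor
compound 2 `Cc1ccc(Nc2nc(SCc3cn(Cc4ccc(Cl)cc4)nn3)nc(-c3ccccc3)c2C#N)cc1` gives > 64000 nM in this assay

Compound 2 stands at the edge of what this assay reports: the reading of compound 2, > 64000 nM, is a limit and not a number (the limit of > 64000 nM in this assay, at which 1 of the 2 values shown sits). Compound 3 `N#Cc1c(Nc2ccccc2F)nc(SCc2cn(Cc3ccc(Cl)cc3)nn2)nc1-c1ccccc1` differs from compound 2 by 2-fluorophenyl in place of 4-methylphenyl on a nitrogen on an aromatic ring. Among the compounds with values here, no measured pair isolates this change, so its size cannot be read from the data. Compound 1 also carries the 2-fluorophenyl group and gives a number in this assay. For compound 3 the step of an at least 1.8-fold lower number from compound 2 to compound 3 (0.26 log units; that floor lies within the scatter) is expected to move it into the measurable range. Compound 3 is estimated at 35000 nM, between 15000 nM and 90000 nM.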

Compound 3, half-maximal inhibitory concentration: > 64000 nM
Compound 3 was reported as a limit; the forecaster's own chance of this, stated with the estimate: 35%; middle value at least 1.8-fold (0.26 log units) from the limit.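

In this assay compound 3 gives > 64000 nM, which is a limit and not a number. Putting 4-chlorophenyl in place of 2-chlorophenyl on a saturated chain carbon bound to an aromatic nitrogen gives an at least 2.7-fold higher number from compound 1 to compound 3 (0.44 log units; beyond the scatter), so this swap matters even with the 2-fluorophenyl group held constant. The step between compound 2 and compound 3 cannot be read, because both readings stand at the edge of the assay: the limit of > 64000 nM in this assay, at which 2 of the 3 values shown sit.

Going by these compounds, it remains open how an unsubstituted phenyl or a methoxyphenyl on that chain carbon would read. On these data alone, it is also open whether 2-chlorophenyl would bring a number alongside the 4-methylphenyl group.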